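The source may report more compounds than this note shows. Statements on the series, on what has been measured and on what is new or still open speak of the compounds shown alone.

Of the compounds shown here, three built on a shared core have been measured in a functional assay on MDA-MB-231 cells (Homo sapiens) for antiproliferative activity, read by MTT assay, with a stated time of 24 h; a higher number here means a weaker inhibitor, a lower number a stronger inhibitor. In that test, compound 2 (`N#Cc1ccc(S(=O)(=O)NC(CC(=O)O)c2ccccc2)cc1`) gives 48700 nM. Compound 3 (`O=C(O)CC(NS(=O)(=O)c1ccccc1)c1ccc(Cl)cc1Cl`) gives 57800 nM, and these two values lie within the usual scatter of each other. Compound 1 (`O=C(O)CC(NS(=O)(=O)c1ccccc1Br)c1ccccc1`) returns only a limit of this assay, > 100000 nM, and not a number.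

Compound 4 (`O=C(O)CC(NS(=O)(=O)c1ccccc1Br)c1ccc(Cl)cc1Cl`) differs from compound 3 by a single change: bromo in place of hydrogen on an aromatic carbon. Put in words, this is bromo in place of hydrogen on an aromatic carbon, turning phenyl into 2-bromophenyl. Among the measured compounds shown here, no measured pair isolates this change, so any expectation rests on indirect ground. Compound 1 also carries the 2-bromophenyl group and stands at its limit of > 100000 nM, so a modest move towards a higher number in this assay is expected, possibly no larger than the scatter. The expected step runs a 1.5-fold higher number from compound 3 to compound 4 (0.17 log units; within the scatter). For compound 4 the estimated value is 85000 nM. The expected range for that estimate runs from 35000 nM to 160000 nM.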

Compound 4, half-maximal inhibitory concentration: > 100000 nM
Compound 4: a limit, no number; the forecaster's own chance of this, stated with the estimate: 45%; middle value at least 1.1-fold (0.07 log units) away from the limit.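

Among the compounds shown here, this is the first pair that isolates bromo in place of hydrogen on an aromatic carbon, turning phenyl into 2-bromophenyl, and in this assay it gives an at least 1.7-fold higher number from compound 3 to compound 4 (0.23 log units; that floor lies within the scatter). From the compounds shown here alone, that floor stays within the usual scatter, so the pair alone does not establish a real loss, and the true size of the step remains unknown. Both compounds shown with the 2-bromophenyl group, one with phenyl and one with 2,4-dichlorophenyl on the chain carbon, return a limit and not a number: the limit of > 100000 nM in this assay, at which 2 of the 4 values shown sit.

The step between compound 1 and compound 4 cannot be read. The compounds shown leave open whether a fluoro or a methoxy group on that same aromatic carbon would still give a number in this assay, and how far the real values of compound 1 and compound 4 lie beyond their limits.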